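A few compounds are considered here, and "the series" means these few. Any claim that something is new, unique, unknown or untested is made for them only; others in the source may bear on it.

Among the measured compounds shown here, compound 2, with the structure `CC(C)C1CC(=O)c2s/c(=N/c3ccccc3)oc2C1`, is one of two compounds measured in a functional assay on ACHN cells (Homo sapiens) for antiproliferative activity, read by sulforhodamine B assay; on this read-out lower numbers stand for stronger inhibition of growth and higher numbers for weaker inhibition of growth. In this assay compound 2 gives 3080 nM, the higher of the two numbers, and its nearest neighbour is compound 1, with the structure `CC1CC(=O)c2s/c(=N/c3ccccc3)oc2C1`, which in this assay gives 2980 nM; the step of a 1.0-fold higher number from compound 1 to compound 2 (0.01 log units; within the scatter) lies within the scatter. Compound 3, with the structure `CC(C)C1CC(=O)c2s/c(=N/C3CCCCC3)oc2C1`, differs from compound 2 by cyclohexyl in place of phenyl on a double-bonded nitrogen, a phenyl leaving and a cyclohexyl entering on a double-bonded nitrogen whose other neighbour is an aromatic carbon. No measured step concerns this position: the only step shown, from compound 1 to compound 2, changes a group on a saturated ring carbon and is within the scatter. There is therefore no basis for expecting a shift beyond the scatter in this assay, and the estimate carries a wide range. The step from compound 2 to compound 3 is expected to be a 1.1-fold higher number from compound 2 to compound 3 (0.06 log units; within the scatter). Compound 3 is estimated to give 3500 nM in this assay, between 800 nM and 15000 nM.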

Compound 3, concentration for 50% growth inhibition: 6700 nM
Beside the measured number, compound 3's estimate is 1.9-fold (0.28 log units) below it, within the range that was stated.
By their numbers in this assay, from the lowest: compounds 1 and 2 (each within the scatter of the next); then compound 3.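

In this assay, among the compounds shown here, the double-bonded nitrogen is the first position where a change exceeds the scatter: cyclohexyl in place of phenyl gives a 2.2-fold higher number from compound 2 to compound 3 (0.34 log units; beyond the scatter), a modest step, whereas the earlier change on a saturated ring carbon gave only a 1.0-fold higher number from compound 1 to compound 2 (0.01 log units; within the scatter). Phenyl and cyclohexyl are both six-membered rings of carbon only, and the aromatic ring goes with the lower number in this single pair. No measurement available here accounts for this difference.

As far as these compounds go, it remains open whether the same change would give a similar step with methyl rather than isopropyl on the saturated ring carbon. Also open, from the compounds shown here alone, is how a pyridine ring, a longer alkyl chain or a phenyl bearing a methoxy group or an amine would behave on this nitrogen.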